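Cytotoxicity notes: amide replacement on compound 2

The compounds below may be only part of what the source reports. "The series", "measured", "known", "first", "only" and "open" are said of these compounds alone.

Compound 1 `COc1ccc(-c2nc3ncc(-c4ccc(F)cc4)cc3[nH]2)cc1`: in a toxicity assay on THP-1 cells (Homo sapiens) for inhibition (a higher number here means that more compound is tolerated, a lower number that less compound is tolerated), compound 1 gives > 100000 nM, a limit of the assay.
Compound 2 `CCCC(=O)Nc1ncc(-c2ccc(OC)cc2)n1C`: in this assay compound 2 gives > 100000 nM, likewise a limit.
Compound 3 `O=C(Nc1ncc(-c2ccccc2)o1)c1ccc(F)cc1`: in this assay compound 3 gives 17000 nM.

Compound 2 thus stands at the limit of > 100000 nM in this assay, at which 2 of the 3 values shown sit, and only a limit is known for it, while compound 3 alone returns a number. Among the measured compounds shown here, no step between measured compounds is available. Compound 4 `COc1ccc(-c2cnc(NC(=O)c3ccncc3)n2C)cc1` differs from compound 2 by pyridin-4-yl in place of propyl on a carbonyl carbon. For the measured compounds named here, with no measured step to lean on, the change expected in this assay is none beyond the scatter, and compound 4 is expected to sit near the same limit as compound 2, a number no higher from compound 2 to compound 4 (the limit leaves the size open). For compound 4 the estimate is 100000 nM, with a range from 30000 nM to 200000 nM.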

Compound 4, half-maximal cytotoxic concentration: > 100000 nM
Compound 4: no number, only a limit; the forecaster's own chance of this, stated with the estimate: 70%; the middle value lies on the limit itself.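

Compound 2 and compound 4 both return only a limit in this assay and no step can be read between them. On these data alone, whether pyridin-4-yl in place of propyl on a carbonyl carbon shifts the tolerated concentration at all remains open.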